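From methoxy to dimethylamino on an aromatic ring

The source may hold more compounds than are shown below. What is called first, only, known or untested is meant among the compounds shown, and "the series" means these compounds.

Among the measured compounds shown here, in a functional assay on HT-29 cells (Homo sapiens) for inhibition, read by MTT assay, with a stated time of 48 h (on this read-out lower numbers stand for stronger inhibition and higher numbers for weaker inhibition), compound 1 `COc1ccc(-n2c(SCc3ccc(F)cc3)nnc2-c2cc(OC)c(OC)c(OC)c2)cc1` gives 50700 nM and compound 2 `COc1ccc(NC(=O)CSc2nnc(-c3cc(OC)c(OC)c(OC)c3)n2-c2ccc(OC)cc2)cc1` gives 45300 nM as the only other number so far, which places the two level within the usual scatter of repeat measurements. Compound 3 `COc1cc(-c2nnc(SCc3ccc(F)cc3)n2-c2ccc(N(C)C)cc2)cc(OC)c1OC` has not yet been measured. It keeps the core of compound 1 and differs at a single place, where the count reads dimethylamino in place of methoxy on an aromatic carbon and the plain description is dimethylamino in place of methoxy on an aromatic carbon, para to a large group. For the measured compounds named here, the one measured step of a 1.1-fold lower number from compound 1 to compound 2 (0.05 log units; within the scatter) lies within the scatter and comes from a change elsewhere, on a saturated chain carbon bound to a sulfur. Going by the values given here, no measured step touches the methoxy group itself, so the data offer no firm direction. The estimated step of a 1.7-fold lower number from compound 1 to compound 3 (0.23 log units; within the scatter) is therefore expected to stay within the scatter, although a larger move cannot be excluded. Compound 3 is estimated at 30000 nM with 3000 nM to 80000 nM as the expected range.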

Compound 3, half-maximal inhibitory concentration: 44300 nM
For compound 3 the middle estimate is 1.5-fold (0.17 log units) below the measured one; low and high end bracket the measured number.
By their numbers in this assay, from the lowest: compounds 3, 2 and 1 (each within the scatter of the next).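

In this assay, placing dimethylamino instead of methoxy on this aromatic carbon, para to a large group, gives a 1.1-fold lower number from compound 1 to compound 3 (0.06 log units; within the scatter), and this step lies within the scatter. Among the compounds shown here, this is the first measured step at this position, since the only earlier step came from a change on a saturated chain carbon bound to a sulfur, so it now shows that going from 4-methoxyphenyl to 4-(dimethylamino)phenyl leaves the two numbers indistinguishable on this read-out. No separate measurement bears on why these two groups read alike here.

With only methoxy and dimethylamino shown at this position, it remains open whether a smaller group such as a fluorine atom, a primary amine, a carboxylic acid or a longer chain such as butoxy would give a number clearly apart from these. On these data alone, it also remains open whether dimethylamino would read the same if the 4-fluorophenyl group on the saturated chain carbon were replaced by the (4-methoxyphenyl)carbamoyl group of compound 2.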